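Phenoxy tail variation in the shared core

The source may report more compounds than this note shows. Statements on the series, on what has been measured and on what is new or still open speak of the compounds shown alone.

Measured compounds:
compound 1 `CC(C)=CCC1Cc2c(OCCCNC(=O)c3cccs3)cc(=O)n(CCCO)c2CC1(C)C` — 33.6%
compound 2 `COc1ccc(OCCCOc2cc(=O)n(CCCO)c3c2CC(CC=C(C)C)C(C)(C)C3)cc1` — 47.7%

Among the compounds with values here, in a functional assay on PANC-1 cells (Homo sapiens) for inhibition, read by MTT assay, with a stated time of 24 h, tested at 10 uM (a lower number here means less inhibition, a higher number more inhibition at the concentration tested (going by the name of the read-out)), compound 2 gives the higher of the two numbers so far; compound 1 lies below it by a number 14.1 percentage points higher from compound 1 to compound 2 (beyond the scatter), a step that exchanged the whole group three bonds along the chain from the aromatic oxygen. Compound 3 `CC(C)=CCC1Cc2c(OCCCOc3ccc(Cl)cc3)cc(=O)n(CCCO)c2CC1(C)C` keeps the phenoxy tail of compound 2 and alters only its ring substituent: chloro in place of methoxy on an aromatic carbon. Within the data shown here, no measured step touches this position; the single step from compound 1 to compound 2 replaced a far larger portion, so it bears on the new change only loosely, and the series gives no direct guide to the size or direction of this smaller exchange. The step from compound 2 to compound 3 in this assay is therefore expected to stay within the scatter, a number 0.3 percentage points higher from compound 2 to compound 3 (within the scatter). Compound 3 is accordingly estimated at 48%, with a range from 32% to 64%.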

Compound 3, a percentage reported as inhibition, at one concentration (the size of the read-out at that concentration, not a potency): 22.7%
For compound 3 the middle estimate is 25.3 percentage points above the measured one; the measured number lies below the stated range.
By their numbers in this assay, from the lowest: compound 3; then compound 1; then compound 2.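

In this assay the substituent on the phenoxy ring clearly affects the read-out: chloro in place of methoxy on this aromatic carbon gives a number 25 percentage points lower from compound 2 to compound 3 (beyond the scatter) and reverses the earlier picture of the phenoxy tail. The exchange of the ((thiophen-2-yl)carbonyl)amino group for 4-methoxyphenoxy gives a number 14.1 percentage points higher from compound 1 to compound 2 (beyond the scatter) whereas the exchange for 4-chlorophenoxy gives a number 10.9 percentage points lower from compound 1 to compound 3 (beyond the scatter) so the direction of that tail exchange depends on the group at this ring carbon. No available evidence accounts for the drop with chloro.

On these data alone, only methoxy and chloro are compared at this ring carbon, so it remains open where an unsubstituted phenoxy, a hydroxyl or a dimethylamino group would fall. As far as these compounds go, whether the methoxy-to-chloro step holds with a longer chain between the core oxygen and the phenoxy group is also open.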